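Hydroxy to methoxy repeated on a second core

A few compounds are considered here, and "the series" means these few. Any claim that something is new, unique, unknown or untested is made for them only; others in the source may bear on it.

Compound 1 `COc1ccc(/C=C2\Cc3c(cc(OC)c(OC)c3OC)C2=O)cc1O` and compound 2 `COc1ccc(/C=C2\Cc3c(cc(OC)c(OC)c3OC)C2=O)cc1OC` share one core; compound 3 `COc1cc2c(cc1O)C(=O)/C(=C/c1cc(OC)c(OC)c(OC)c1)C2` and compound 4 `COc1cc2c(cc1OC)C(=O)/C(=C/c1cc(OC)c(OC)c(OC)c1)C2` share another, built from the same atoms as compound 1 joined differently, and the difference between the two cores is not broken down here. In a functional assay on PC-3 cells (Homo sapiens) for antiproliferative activity, read by MTT assay, with a stated time of 48 h (a lower number here means a stronger inhibitor of growth, a higher number a weaker inhibitor of growth), compound 1 gives 213 nM. In this assay compound 2 gives 7470 nM, the step of a 35-fold higher number from compound 1 to compound 2 (1.54 log units; beyond the scatter) following (methyl in place of hydrogen on an oxygen on an aromatic ring). In this assay compound 3 is known only as a limit, > 10000 nM, which is the limit of > 10000 nM in this assay, at which 1 of the 3 values shown sits. The change to compound 4, (methyl in place of hydrogen on an oxygen on an aromatic ring), is the same change in the same place. The step that the limit leaves unreadable from compound 3 to compound 4 is expected to run in the same direction, because the earlier step of a 35-fold higher number from compound 1 to compound 2 (1.54 log units; beyond the scatter) was large. Compound 4 is therefore estimated at 30000 nM, within 10000 nM to 150000 nM, most likely reported only as a limit.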

Compound 4, concentration for 50% growth inhibition: > 10000 nM
Compound 4: a limit, no number (the forecaster's own chance of this, stated with the estimate: 85%); the middle value does not contradict the limit.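

Compound 3 and compound 4 both stand only as limits in this assay, so the hydroxy to methoxy step between them cannot be read: the limit of > 10000 nM in this assay, at which 2 of the 4 values shown sit.

On these data alone, whether the core of compound 3 responds to this change as the core of compound 1 does stays open.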